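Pyridin-4-yl in place of 4-methylphenyl: compound 3

The compounds below may be only part of what the source reports. "The series", "measured", "known", "first", "only" and "open" are said of these compounds alone.

Measured in a physicochemical assay for solubility, in phosphate buffer, at pH 7.4; a lower number here means a less soluble compound, a higher number a more soluble compound:
- compound 1 `COCC1CCN(c2nccnc2OC2CN(c3ccc4ccccc4n3)C2)CC1`: 53000 nM
- compound 2 `Cc1ccc(-c2nccnc2OC2CN(c3ccc4ccccc4n3)C2)cc1`: < 1000 nM (a limit)

Compound 2 stands only at a limit, < 1000 nM, and has no number of its own. Compound 3 `c1ccc2nc(N3CC(Oc4nccnc4-c4ccncc4)C3)ccc2c1` carries the change (pyridin-4-yl in place of 4-methylphenyl on an aromatic carbon). Going by the values given here, the one measured step at this place is an at least 53-fold lower number from compound 1 to compound 2 (1.72 log units; beyond the scatter), which is large but involves a different group, so it shows only that the read-out can move widely here. In this assay, a moderate step to a higher number is expected, with a real chance of none. The expected step is an at least 3.0-fold higher number from compound 2 to compound 3 (0.47 log units; beyond the scatter). Compound 3 is estimated at 3000 nM, with an expected range of 800 nM to 15000 nM.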

Compound 3, solubility: 56000 nM
Compound 3: middle estimate off by 19-fold (1.27 log units), on the low side; the measured number lies above the stated range.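

In this assay, pyridin-4-yl in place of 4-methylphenyl gives an at least 56-fold higher number from compound 2 to compound 3 (1.74 log units; beyond the scatter), so the low result of compound 2 is not shared by every six-membered aromatic ring at this place. Pyridin-4-yl and 4-(methoxymethyl)piperidin-1-yl are not separated here: a 1.1-fold higher number from compound 1 to compound 3 (0.02 log units; within the scatter). The first step has no upper size, as compound 2 has only a limit and no number of its own: the limit of < 1000 nM in this assay, at which 1 of the 3 values shown sits.

Still open, as far as these compounds go, is whether the step follows the ring nitrogen of pyridin-4-yl or the missing methyl, which plain phenyl would separate. Also open, from the compounds shown here alone, is how a carboxylic acid on that aromatic ring would read.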